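Lengthening the chain of compound 3

The source may hold more compounds than are shown below. What is called first, only, known or untested is meant among the compounds shown, and "the series" means these compounds.

For the measured compounds named here, in a functional assay on WiDr cells (Homo sapiens) for antiproliferative activity, read by sulforhodamine B assay, with a stated time of 48 h (a lower number here means a stronger inhibitor of growth, a higher number a weaker inhibitor of growth), compound 3 `CCCCCCCCC[C@@H](O)[C@@H](N)[C@@H](C)CC` gives 2300 nM, the lowest of the three numbers so far. Compound 1 `CCCCCCCCCCCCCCC[C@@H](O)[C@@H](N)[C@@H](C)O` gives 18000 nM and compound 2 `CCCCCCCCCCCCCCC[C@@H](O)[C@@H](N)C(C)C` gives 20000 nM, each beyond the scatter from compound 3.

Compound 4 `CCCCCCCCCCCCCCC[C@@H](O)[C@@H](N)[C@@H](C)CC` differs from compound 3 by hexyl in place of hydrogen on a saturated chain carbon, ten or more bonds along the chain from an oxygen on a saturated carbon. Going by the values given here, no measured step covers this change directly. Among the compounds with values here, the one measured step, a 1.1-fold higher number from compound 1 to compound 2 (0.05 log units; within the scatter), concerns isopropyl in place of 1-hydroxyethyl and stays within the scatter. Within the data shown here, with only that step available, the end group offers little guide, and the chain carries the expectation. Compound 4 shares its chain with compound 1 at 18000 nM and with compound 2 at 20000 nM, so a number near theirs is expected in this assay. The expected change is a rise beyond the scatter, an estimated 6.5-fold higher number from compound 3 to compound 4 (0.81 log units; beyond the scatter). The estimate for compound 4 is 15000 nM, with an expected range of 6000 nM to 30000 nM.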

Compound 4, concentration for 50% growth inhibition: 13000 nM
Compound 4: middle estimate off by 1.2-fold (0.06 log units), on the high side; measured number inside the range.
By their numbers in this assay, from the lowest: compound 3; then compounds 4, 1 and 2 (each within the scatter of the next).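

In this assay, for the compounds shown here, the first measured change on the chain gives a 5.7-fold higher number from compound 3 to compound 4 (0.75 log units; beyond the scatter), so hexyl in place of hydrogen on a saturated chain carbon, ten or more bonds along the chain from an oxygen on a saturated carbon, goes beyond the scatter. With the longer chain held, the two new changes at the other end of the molecule stay within the scatter: a 1.5-fold lower number from compound 2 to compound 4 (0.19 log units; within the scatter) for methyl in place of hydrogen, three bonds along the chain from an amine nitrogen, and a 1.4-fold lower number from compound 1 to compound 4 (0.14 log units; within the scatter) for ethyl in place of hydroxy. Nothing available explains the size of the chain step.

Going by these compounds alone, only two chain lengths appear, so the trend across intermediate, shorter or still longer chains remains open. Also open, going by these compounds, is whether an amine or a carboxylic acid in place of the hydroxy would keep the number within the scatter on the longer chain.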